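From 3-fluorophenyl to 3,4-dichlorophenyl: a solubility estimate

The compounds below may be only part of what the source reports. "The series", "measured", "known", "first", "only" and "open" are said of these compounds alone.

Measured in a physicochemical assay for solubility, in phosphate buffer, at pH 7.4; a lower number here means a less soluble compound, a higher number a more soluble compound:
- compound 1 `CCOC(=O)c1c(-c2cccc(F)c2)[nH]c2cccc(OC)c2c1=O` gives > 100000 nM (a limit)
- compound 2 `CCOC(=O)c1c(-c2ccc(Cl)c(Cl)c2)[nH]c2cc(OC)ccc2c1=O` gives 17000 nM
- compound 3 `CCOC(=O)c1c(-c2cccc(C(F)(F)F)c2)[nH]c2cccc(OC)c2c1=O` gives > 100000 nM (a limit)

Compound 1 stands at > 100000 nM in this assay as a limit of the assay and not a number. The set is marked by the limit of > 100000 nM in this assay, at which 2 of the 3 values shown sit, and so offers little room for reading steps.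

The change to compound 4 `CCOC(=O)c1c(-c2ccc(Cl)c(Cl)c2)[nH]c2cccc(OC)c2c1=O` puts 3,4-dichlorophenyl in place of 3-fluorophenyl on an aromatic carbon and leaves the rest of the core of compound 1 as it is.

For the measured compounds named here, the one measured step is a step that the two limits leave unreadable from compound 1 to compound 3 and gives no size to carry over. The nearest guide is compound 2, which carries the same 3,4-dichlorophenyl group on a different core and gives 17000 nM as a true number. Compound 4 is therefore expected to lie close to compound 2 at 17000 nM, although this rests on a single compound. The estimated change is an at least 4.0-fold lower number from compound 1 to compound 4 (0.60 log units; beyond the scatter) and points downward in this assay, well beyond the scatter. For compound 4 the expected solubility is 25000 nM (estimated range 7000 nM to 90000 nM).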

Compound 4, solubility: 39000 nM
Beside the measured number, compound 4's estimate is 1.6-fold (0.19 log units) below it; the measured number falls inside the stated range.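

Next to the ring nitrogen on the core of compound 1, 3,4-dichlorophenyl in place of 3-fluorophenyl gives the first step at this position that can be read in this assay: an at least 2.5-fold lower number from compound 1 to compound 4 (0.40 log units; beyond the scatter). Compound 1 gives > 100000 nM, which is a limit of the assay and not a number. From the compounds shown here alone, the true size of the step therefore stays unknown, and the step to the trifluoromethyl compound cannot be read, because both depend on the same ceiling: the limit of > 100000 nM in this assay, at which 2 of the 4 values shown sit.

Going by these compounds, it remains open whether a single chlorine, as in 3-chlorophenyl or 4-chlorophenyl, would keep a compound at the limit or bring it down to a number. Also open, on these data alone, is what a phenyl ring carrying an amine or a carboxylic acid would do at this carbon.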